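The source may hold more compounds than are shown below. What is called first, only, known or untested is meant among the compounds shown, and "the series" means these compounds.

Measured so far:
- compound 1 `Nc1ccccc1NC(=O)c1ccc(CSc2ccc(Br)cc2)cc1`: 33.2%
- compound 2 `Nc1ccccc1NC(=O)/C=C/c1ccc(CSc2ccc(F)cc2)cc1`: 51.2%
- compound 3 `Nc1ccccc1NC(=O)c1ccc(CSc2ccc(C(F)(F)F)cn2)cc1`: 37.1%

In a functional assay on A549 cells (Homo sapiens) for inhibition, read by CCK-8 assay, with a stated time of 72 h, tested at 2 uM (a higher number here means more inhibition of growth at the concentration tested, a lower number less inhibition of growth), compound 1 gives the lowest of the three numbers. Compound 3 stands closest to it, and the two values lie within the scatter of each other, so no order between compound 1 and compound 3 can be read from them. Compound 2 stands furthest, its number being beyond the scatter above that of compound 1; compound 2 differs from compound 1 in more than one place, so this gap cannot be tied to a single change.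

Compound 4 `CC(C)(C)c1ccc(SCc2ccc(C(=O)Nc3ccccc3N)cc2)cc1` is not yet measured. It differs from compound 1 by tert-butyl in place of bromo on an aromatic carbon. For the measured compounds named here, no pair of measured compounds shows this change, or any single change, on its own, so there is no measured step to rest on. The expectation is a small step, at most slightly upward, and quite possibly none beyond the scatter: a number 4.8 percentage points higher from compound 1 to compound 4 (within the scatter). Compound 4 is estimated at 38% in this assay, with a range from 22% to 55%.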

Compound 4, percent growth inhibition at one concentration: 38.6%
Compound 4: middle estimate off by 0.6 percentage points, on the low side, within the range that was stated.
By their numbers in this assay, from the lowest: compounds 1, 3 and 4 (each within the scatter of the next); then compound 2.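

In this assay, tert-butyl in place of bromo on an aromatic carbon, para to a large group, gives a number 5.4 percentage points higher from compound 1 to compound 4 (within the scatter). For the compounds shown here, this is the first single-place step, and it shows that at this position a group of four carbon atoms and a single bromine atom cannot be told apart within the scatter, so this exchange gives no measurable gain or loss of growth inhibition at the concentration tested. No measurement at hand bears on why the two groups read alike.

From the compounds shown here alone, whether a group of a different kind at this position, such as an amine or a carboxylic acid, would move the number beyond the scatter remains open. Compound 2, at 51.2%, also remains untied to any single change, so the part played by its other differences from the series is unresolved.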